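A few compounds are considered here, and "the series" means these few. Any claim that something is new, unique, unknown or untested is made for them only; others in the source may bear on it.

Within the data shown here, in a physicochemical assay for solubility, using the shake flask method, in phosphate buffer, at pH 7 (on this read-out higher numbers stand for higher solubility and lower numbers for lower solubility), compound 2 `COc1ccc(-c2ccc(C(=O)O)cc2C)cc1-c1cnc(N(C)C)nc1CN1C(=O)O[C@H](c2cc(C(F)(F)F)cc(C(F)(F)F)c2)[C@@H]1C` gives 43000 nM, the higher of only two measured numbers. The other number belongs to compound 1 `COc1ccc(-c2ccc(C(=O)O)cc2C)cc1-c1cnc(C(F)(F)F)nc1CN1C(=O)O[C@H](c2cc(C(F)(F)F)cc(C(F)(F)F)c2)[C@@H]1C`, which gives 6000 nM. Compound 3 `COc1ncc(-c2cc(-c3ccc(C(=O)O)cc3C)ccc2OC)c(CN2C(=O)O[C@H](c3cc(C(F)(F)F)cc(C(F)(F)F)c3)[C@@H]2C)n1` has not yet been measured. It keeps the rest of compound 2 and changes one group: methoxy in place of dimethylamino on an aromatic carbon. This puts methoxy in place of dimethylamino on an aromatic carbon, between two ring nitrogen atoms. Among the measured compounds shown here, only one measured step concerns this same place: a 7.2-fold higher number from compound 1 to compound 2 (0.86 log units; beyond the scatter), a modest step beyond the scatter, with dimethylamino in place of trifluoromethyl. Methoxy itself is untested here, so that step is only a loose guide, and a landing somewhere inside its span is expected. The expected change is a moderate drop, a 2.9-fold lower number from compound 2 to compound 3 (0.46 log units; beyond the scatter). Compound 3 is estimated at 15000 nM, with an expected range from 5000 nM to 45000 nM.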

Compound 3, solubility: 52000 nM
The estimate for compound 3 lay 3.5-fold (0.54 log units) below the measured number; the whole stated range lies below it.
By their numbers in this assay, from the lowest: compound 1; then compounds 2 and 3 (each within the scatter of the next).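

In this assay, methoxy in place of dimethylamino on the aromatic carbon between two ring nitrogen atoms gives a 1.2-fold higher number from compound 2 to compound 3 (0.08 log units; within the scatter) and so leaves the two groups indistinguishable on this read-out. Methoxy in place of trifluoromethyl at the same place gives an 8.7-fold higher number from compound 1 to compound 3 (0.94 log units; beyond the scatter) and shows that a second group, besides dimethylamino, stands clear of trifluoromethyl here. Among these three compounds, trifluoromethyl is thus the one group that sits apart, although nothing measured here explains this.

Still open, from the compounds shown here alone, is where other groups at this place would land, such as a primary amine, a longer chain like ethoxy, or a plain hydrogen. Also open, going by these compounds, is whether the same match between methoxy and dimethylamino would hold with changes elsewhere on the shared core.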